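A few compounds are considered here, and "the series" means these few. Any claim that something is new, unique, unknown or untested is made for them only; others in the source may bear on it.

Working notes on the series. For the measured compounds named here, two members have been measured so far: compound 1 `COc1cc(-c2nnc(SCC(=O)Nc3ccc(/C(C)=N/O)cc3)n2-c2ccccc2)cc(OC)c1OC` and compound 2 `C=CCn1c(SCC(=O)Nc2ccc(/C(C)=N/O)cc2)nnc1-c1ccc(OC)c(OC)c1`, which differ from each other in more than one place, so no single-change step connects them. In a functional assay on the whole organism (strain albino) for inhibition, with Rattus norvegicus as the target, read by paw edema, with stated times of 30 min and 1 h, at a dose of 0.28 mmol/kg by the oral route (on this read-out lower numbers stand for less inhibition and higher numbers for more inhibition at the one dose given (going by the name of the read-out)), compound 1 gives 59%, and compound 2 gives 53%. Going by the values given here, on these two numbers compound 2 stands at the lower value, with compound 1 its only and nearest neighbour, and the gap between them lies within the usual scatter; the two values therefore show no real separation.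

Compound 3 `C=CCn1c(SCC(=O)Nc2ccc(/C(C)=N/O)cc2)nnc1-c1cc(OC)c(OC)c(OC)c1` is the next point to be measured in this assay. It differs from compound 2 by methoxy in place of hydrogen on an aromatic carbon, the new group sitting ortho to a methoxy group already present. Among the compounds with values here, no measured pair isolates this change, so there is no step to lean on. The change a number 3 percentage points higher from compound 2 to compound 3 (within the scatter) is expected to be small, in no sure direction, and not beyond the scatter. Compound 3 is estimated at 56%, within a range of 44% to 68%.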

Compound 3, a percentage reported as inhibition, in the whole organism at one dose (the size of the read-out at that dose, not a potency): 49%
For compound 3 the middle estimate is 7 percentage points above the measured one; the measured number falls inside the stated range.
By their numbers in this assay, from the lowest: compounds 3, 2 and 1 (each within the scatter of the next).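

In this assay, methoxy in place of hydrogen on this aromatic carbon, ortho to a methoxy group, now has a step of its own: a number 4 percentage points lower from compound 2 to compound 3 (within the scatter), so this change shows no real separation with allyl on the aromatic nitrogen. The nitrogen substituent can now be read alone as well, allyl in place of phenyl giving a number 10 percentage points lower from compound 1 to compound 3 (within the scatter), so neither single change has yet moved the read-out beyond the scatter at this one dose. No measured evidence bears on what lies behind these two steps.

Going by these compounds, each change rests on a single pair, so whether the methoxy step would read the same with phenyl on the aromatic nitrogen stays open. Also open, on these data alone, is whether a hydroxyl or an amine on this aromatic carbon, or a longer chain in place of allyl, would give a step beyond the scatter.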